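This account rests on a few compounds, and the source may have more. Where it says the series, first, only, none or still open, it means among the compounds named here.

Working notes on the series. All four compounds share one core; compound 1 `CC(=O)N[C@@H]1CCCc2c1cncc2N1C(=O)c2ccc(Cl)cc2[C@@H]1C1CC1` carries a cyclopropyl on the saturated ring carbon, compound 2 `CC(=O)N[C@@H]1CCCc2c1cncc2N1C(=O)c2ccc(Cl)cc2[C@@H]1C` a methyl, and compound 3 `CCC(=O)N[C@@H]1CCCc2c1cncc2N1C(=O)c2ccc(Cl)cc2[C@@H]1CC` an ethyl together with a propanoylamino group where the first two have acetamido. In an assay on cells for inhibition of cytochrome P450 11B2, mitochondrial (Homo sapiens), read by HTRF (on this read-out higher numbers stand for weaker inhibition and lower numbers for stronger inhibition), compound 1 gives 354 nM, compound 2 gives 4 nM and compound 3 gives 12 nM. Within the data shown here, the only single-point step measured so far is an 89-fold lower number from compound 1 to compound 2 (1.95 log units; beyond the scatter). On the three numbers compound 3 stands second highest, with compound 2 nearest and compound 1 furthest.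

Compound 4 `CC[C@H]1c2cc(Cl)ccc2C(=O)N1c1cncc2c1CCC[C@H]2NC(C)=O` differs from compound 3 by hydrogen in place of methyl on a saturated chain carbon bound to a carbonyl carbon, read one bond further out as propanoyl to acetyl; it thus combines the ethyl of compound 3 with the acetamido group of compound 2. Among the measured compounds shown here, no measured step touches the amide side: the step from compound 1 to compound 2 sits on the ring carbon and does not bear on it. Compound 2 differs from compound 3 in both places at once, so its value and that of compound 3 only bracket the region. In this assay the step from compound 3 to compound 4 is expected to be modest, toward a lower number, a 1.7-fold lower number from compound 3 to compound 4 (0.23 log units; within the scatter). Compound 4 is estimated at 7 nM, within 2.5 nM to 20 nM.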

Compound 4, half-maximal inhibitory concentration: 97 nM
Beside the measured number, compound 4's estimate is 14-fold (1.14 log units) below it; the whole stated range lies below it.
By their numbers in this assay, from the lowest: compound 2; then compound 3; then compound 4; then compound 1.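

In this assay, with the ethyl held, propanoylamino to acetamido gives an 8.1-fold higher number from compound 3 to compound 4 (0.91 log units; beyond the scatter), so the amide side, untouched by any earlier step, clearly affects the number; on this ethyl background, the propanoylamino compound is the stronger of the two. On the saturated ring carbon, with acetamido held, methyl to ethyl gives a 24-fold higher number from compound 2 to compound 4 (1.38 log units; beyond the scatter) and cyclopropyl to ethyl gives a 3.6-fold lower number from compound 1 to compound 4 (0.56 log units; beyond the scatter), which places ethyl between methyl and cyclopropyl. The earlier step from cyclopropyl to methyl therefore resolves into two parts, and the larger part lies between ethyl and methyl, so adding a single methyl at this carbon already costs much of the range seen in the series.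

The compounds shown do not tell whether the gain from propanoylamino carries over to the methyl or cyclopropyl compounds, or whether it continues to a butanoylamino group or to a propyl on the ring carbon. Nothing available here accounts for the sensitivity at either place, and the steps stand as measured differences only.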